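The compounds below may be only part of what the source reports. "The series", "measured", "known", "first", "only" and "open" are said of these compounds alone.

Measured so far in a functional assay on L1210 cells (Mus musculus) for inhibition, read by MTT assay, with a stated time of 72 h; on this read-out higher numbers stand for weaker inhibition and lower numbers for stronger inhibition:
compound 1 `COc1cc(NC(C)CCCNC(=O)NNC(=O)Nc2ccc(F)cc2)c2ncccc2c1` gives 104000 nM
compound 2 `COc1cc(NC(C)CCCNC(=O)Nc2cccc(O)c2)c2ncccc2c1` gives 25000 nM
compound 3 `COc1cc(NC(C)CCCNC(=O)Nc2ccc(C(F)(F)F)cc2)c2ncccc2c1` gives 7400 nM

Compound 1 carries the highest number of the three and so shows the weakest inhibition. The nearest value lies at a 4.2-fold lower number from compound 1 to compound 2 (0.62 log units; beyond the scatter) and the furthest at a 14-fold lower number from compound 1 to compound 3 (1.15 log units; beyond the scatter).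

Next is compound 4 `COc1cc(NC(C)CCCNC(=O)NNC(=O)Nc2cccc(C(F)(F)F)c2)c2ncccc2c1`, not yet measured, with 3-(trifluoromethyl)phenyl in place of 4-fluorophenyl on an amide-type nitrogen. Within the data shown here, no measured step makes this change with the rest of compound 1 kept. The closest guide is the modest 3.4-fold lower number from compound 2 to compound 3 (0.53 log units; beyond the scatter), where only the aryl group changes and a trifluoromethyl-bearing group enters. The large 14-fold lower number from compound 1 to compound 3 (1.15 log units; beyond the scatter) bears on it only in part, since that step also removes the carbamoylamino link that compound 4 keeps. A modest step towards a lower number is therefore expected in this assay. The expected size is a 3.0-fold lower number from compound 1 to compound 4 (0.47 log units; beyond the scatter). The estimated value for compound 4 is 35000 nM, with a range from 10000 nM to 100000 nM.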

Compound 4, half-maximal inhibitory concentration: 4000 nM
For compound 4 the middle estimate is 8.8-fold (0.94 log units) above the measured one; measured number outside the range, below it.
By their numbers in this assay, from the lowest: compounds 4 and 3 (each within the scatter of the next); then compound 2; then compound 1.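

In this assay, exchanging only the aryl group on an amide-type nitrogen, with the carbamoylamino link kept, gives a 26-fold lower number from compound 1 to compound 4 (1.41 log units; beyond the scatter) and shows that this position responds strongly to the aryl group alone. The earlier steps shown here from compound 1 all removed the link as well, so they could not separate the two changes; compound 4 shows that keeping the link does not by itself hold the number high. Nothing at hand explains why this exchange has so large an effect.

The step changes both the substituent and its place on the ring, so the shares of trifluoromethyl and of its place remain unresolved; 3-fluorophenyl and 4-(trifluoromethyl)phenyl on the same link would separate them. From the compounds shown here alone, how an amine or a carboxylic acid on that phenyl ring would read also remains open.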